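Compound 4: A New Ring on the Shared Core

The compounds below may be only part of what the source reports. "The series", "measured", "known", "first", "only" and "open" are said of these compounds alone.

Measured so far:
compound 1 `O=C1NCCC12CCN(c1c(Cl)cncc1-c1ccc(Cl)s1)CC2` — 560 nM
compound 2 `O=C1NCCC12CCN(c1c(Cl)cncc1-c1ccc(-c3ccccc3)s1)CC2` — 960 nM
compound 3 `O=C1NCCC12CCN(c1c(Cl)cncc1-c1ccc(CN3CCCC3)s1)CC2` — 3370 nM

In a functional assay on MV4-11 cells (Homo sapiens) for inhibition, read by resazurin assay, with a stated time of 72 h (a higher number here means a weaker inhibitor of growth, a lower number a stronger inhibitor of growth), compound 1 holds the lowest of the three numbers, though compound 2 lies within the scatter of it; compound 3 stands further off. Compound 4 `O=C1NCCC12CCN(c1c(Cl)cncc1-c1cnn(C(F)F)c1)CC2` differs from compound 1 by 1-(difluoromethyl)-1H-pyrazol-4-yl in place of 5-chlorothiophen-2-yl on an aromatic carbon. Within the data shown here, no measured step swaps the whole ring; the nearest are a 1.7-fold higher number from compound 1 to compound 2 (0.23 log units; within the scatter) and a 6.0-fold higher number from compound 1 to compound 3 (0.78 log units; beyond the scatter), both changes made within the 5-chlorothiophen-2-yl group. Those steps ran from within the scatter to modest, all toward higher numbers, so a modest rise in this assay is expected for compound 4, with wide uncertainty. The estimate for compound 4 is 1400 nM, between 450 nM and 4500 nM, which means an expected step of a 2.5-fold higher number from compound 1 to compound 4 (0.40 log units; beyond the scatter).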

Compound 4, concentration for 50% growth inhibition: 6140 nM
The estimate for compound 4 lay 4.4-fold (0.64 log units) below the measured number; the measured number lies above the stated range.
By their numbers in this assay, from the lowest: compounds 1 and 2 (each within the scatter of the next); then compounds 3 and 4 (each within the scatter of the next).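

In this assay, the exchange of 5-chlorothiophen-2-yl for 1-(difluoromethyl)-1H-pyrazol-4-yl gives an 11-fold higher number from compound 1 to compound 4 (1.04 log units; beyond the scatter), the only large step shown and the only one that replaces the whole ring on this aromatic carbon. The earlier steps shown here changed only the group carried by the thiophene, so this one shows that the number at this position also responds to an exchange of the ring itself. No measurement shown here explains the rise.

Going by these compounds, whether the pyrazole ring or its difluoromethyl group carries the step stays open. So does how a 1-methyl-1H-pyrazol-4-yl group would stand at this position.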